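Dropping a Methyl from a Short Fluorinated Alcohol

The compounds below may be only part of what the source reports. "The series", "measured", "known", "first", "only" and "open" are said of these compounds alone.

Three small alcohols have been measured in a physicochemical assay for lipophilicity, read by NMR; a higher number here means a more lipophilic compound, a lower number a more polar compound. Compound 1, `CC(F)(F)CCCO`, gives 0.71. Compound 2, `CCCC(F)CO`, gives 0.87, and compound 3, `CC(=O)N1CCC[C@H]1C(=O)OCC(F)(F)F`, gives 0.55. The value of compound 1 lies within the usual scatter of both compound 2 and compound 3, so the three numbers do not separate compound 1 from either neighbour with any confidence.

The next compound, compound 4, `OCCCC(F)F`, has not yet been measured in this assay. It differs from compound 1 in one place: hydrogen in place of methyl on a saturated chain carbon bound to two fluorine atoms and a saturated chain carbon. The chain is shortened by that one carbon, and nothing else about the compound changes. Among the measured compounds shown here, no pair of measured compounds in this set differs by such a single change, so there is no measured step to lean on.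

Losing a carbon from a saturated chain usually makes a compound read as more polar in this assay. On that basis compound 4 is expected to come out lower than compound 1, with a step of a number 0.51 log units lower from compound 1 to compound 4 (beyond the scatter) that should exceed the scatter. The estimate for compound 4 is 0.2, within a range of -0.05 to 0.45.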

Compound 4, partition coefficient: 0.29
The estimate for compound 4 lay 0.09 log units below the measured number; the range from low to high includes it.
By their numbers in this assay, from the lowest: compounds 4, 3, 1 and 2 (each within the scatter of the next, the first and the last beyond it).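

Among the compounds shown here, this is the first one-place comparison in the set: in this assay, hydrogen in place of methyl on a saturated chain carbon bound to two fluorine atoms and a saturated chain carbon gives a number 0.42 log units lower from compound 1 to compound 4 (beyond the scatter) and so a step that stands clear of the usual scatter. The earlier compounds shown here could not show this, since they differ from one another in more than one place and offered no single change to read. Nothing at hand accounts for the size or direction of this step.

A single pair also leaves open whether the same change would give a similar step on another chain. Going by these compounds, what an ethyl group, a longer chain or a single fluorine atom would do on this carbon also remains open.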